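Thiophen-3-yl in place of furan-3-yl

A few compounds are considered here, and "the series" means these few. Any claim that something is new, unique, unknown or untested is made for them only; others in the source may bear on it.

In a functional assay on HepG2 cells (Homo sapiens) for antiproliferative activity, read by XTT assay, with a stated time of 72 h (a lower number here means a stronger inhibitor, a higher number a weaker inhibitor), compound 1 (`CSc1ncnc2c1c(-c1ccsc1)cn2[C@@H]1O[C@H](CO)[C@@H](O)[C@H]1O`) reports only a limit (> 15000 nM). Going by the values given here, compound 2 (`Cc1ncnc2c1c(-c1ccoc1)cn2[C@@H]1O[C@H](CO)[C@@H](O)[C@H]1O`) gives 5320 nM in this assay, the only actual number available in this small set. Compound 3 (`Cc1ncnc2c1c(-c1ccsc1)cn2[C@@H]1O[C@H](CO)[C@@H](O)[C@H]1O`) carries thiophen-3-yl in place of furan-3-yl on an aromatic carbon. Among the compounds with values here, no measured pair shows this exchange, so a change within the usual scatter, with no firm direction, is expected in this assay. The estimated step (a 1.1-fold higher number from compound 2 to compound 3 (0.05 log units; within the scatter)) is accordingly expected to be small. Compound 3 is expected at 6000 nM (estimated range 1800 nM to 15000 nM).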

Compound 3, half-maximal inhibitory concentration: 4720 nM
Compound 3: middle estimate off by 1.3-fold (0.10 log units), on the high side; the range from low to high includes it.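

Exchanging furan-3-yl for thiophen-3-yl on this aromatic carbon gives a 1.1-fold lower number from compound 2 to compound 3 (0.05 log units; within the scatter) in this assay, so the two rings cannot be told apart at this position. With thiophen-3-yl held in place, methyl in place of methylsulfanyl on an aromatic carbon gives an at least 3.1-fold lower number from compound 1 to compound 3 (0.50 log units; beyond the scatter), a change beyond what the ring exchange shows. That step is only a bound, as compound 1 reports a limit: the limit of > 15000 nM in this assay, at which 1 of the 3 values shown sits.

The compounds shown leave open whether a group of another kind at the ring position, such as an amine or a phenyl ring, would shift the number beyond the scatter.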